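Nitro to trifluoromethyl: the step to compound 3

The compounds below may be only part of what the source reports. "The series", "measured", "known", "first", "only" and "open" are said of these compounds alone.

Among the compounds with values here, in a functional assay on SMMC-7721 cells (Homo sapiens) for cytotoxicity, read by MTT assay, with a stated time of 24 h (a lower number here means a stronger inhibitor, a higher number a weaker inhibitor), compound 2 `O=C1/C(=C/c2cccnc2)CN(S(=O)(=O)c2ccc([N+](=O)[O-])cc2)C/C1=C\c1ccccc1C(F)(F)F` gives 15900 nM as the higher of the two numbers so far, which makes it the weaker inhibitor of the pair. Within the data shown here, the only other measured member, compound 1 `Cc1ccc(S(=O)(=O)N2C/C(=C\c3cccnc3)C(=O)/C(=C/c3ccccc3C(F)(F)F)C2)cc1`, gives 6700 nM in the same read-out.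

Compound 3 `O=C1/C(=C/c2cccnc2)CN(S(=O)(=O)c2ccc(C(F)(F)F)cc2)C/C1=C\c1ccccc1C(F)(F)F` keeps the shared core and changes one group. The difference trifluoromethyl in place of nitro on an aromatic carbon reads in words as trifluoromethyl in place of nitro on an aromatic carbon, para to a large group, or 4-nitrophenyl to 4-(trifluoromethyl)phenyl.

Among the measured compounds shown here, one measured step bears on this, also a swap on an aromatic carbon: a 2.4-fold higher number from compound 1 to compound 2 (0.38 log units; beyond the scatter) for nitro in place of methyl. For the measured compounds named here, that modest step gives the scale of such a swap in this assay so far. Going by the values given here, no measured compound carries 4-(trifluoromethyl)phenyl, so the direction is not fixed by the data. A small drop no larger than that step is expected, most likely not beyond the scatter. The estimated move is a 1.5-fold lower number from compound 2 to compound 3 (0.18 log units; within the scatter) on this reasoning. For compound 3 the expected value is 10500 nM with an estimated range from 5000 nM to 22000 nM at this stage.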

Compound 3, half-maximal inhibitory concentration: 1730 nM
The estimate for compound 3 lay 6.1-fold (0.78 log units) above the measured number; the whole stated range lies above it.
By their numbers in this assay, from the lowest: compound 3; then compound 1; then compound 2.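

In this assay, the group on this aromatic carbon, para to a large group, moves the number further than the first pair suggested: a 9.2-fold lower number from compound 2 to compound 3 (0.96 log units; beyond the scatter) is a much larger move than a 2.4-fold higher number from compound 1 to compound 2 (0.38 log units; beyond the scatter). Trifluoromethyl also improves on methyl, with a 3.9-fold lower number from compound 1 to compound 3 (0.59 log units; beyond the scatter), so compound 3 is the strongest inhibitor of the three, and the order from lowest number to highest runs trifluoromethyl, methyl, nitro. No measurement shown here accounts for this order or for the size of the trifluoromethyl gain.

Three groups at one position cannot show whether the low number belongs to trifluoromethyl alone or would also appear with other groups in the same place, such as a chlorine atom, a methoxy group, an amine or a carboxylic acid. As far as these compounds go, it also remains open whether the same order would hold if the other parts of the shared core were changed, or in any cell line other than the one used in this assay.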